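This account rests on a few compounds, and the source may have more. Where it says the series, first, only, none or still open, it means among the compounds named here.

Three compounds of the shared core, differing only in the group on the amide nitrogen, have been measured in an ADME assay on HepG2 2.2.15 cells (Homo sapiens) for cytotoxicity, read by MTT assay, with stated times of 48 h and 9 days; on this read-out higher numbers stand for lower toxicity in this test and lower numbers for higher toxicity in this test. Compound 1 `COc1ccc2c(=O)c(/C=C/C(=O)Nc3cccc(Cl)c3)coc2c1` gives 1100000 nM. Compound 2 `COc1ccc2c(=O)c(/C=C/C(=O)Nc3ccccc3C)coc2c1` gives 59700 nM. Compound 3 `COc1ccc2c(=O)c(/C=C/C(=O)NCc3ccc(F)cc3F)coc2c1` gives 79300 nM, which places it second highest of the three: its step from compound 2 is small (a 1.3-fold higher number from compound 2 to compound 3 (0.12 log units; within the scatter)), while the step from compound 1 is large (a 14-fold lower number from compound 1 to compound 3 (1.14 log units; beyond the scatter)).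

Compound 4 `CCOc1ccc(NC(=O)/C=C/c2coc3cc(OC)ccc3c2=O)cc1` is now to be measured in this assay. It differs from compound 3 by 4-ethoxyphenyl in place of 2,4-difluorobenzyl on an amide-type nitrogen. For the measured compounds named here, no measured step exchanges a benzyl group for a phenyl group carrying an oxygen substituent, so the nearest guides are the two earlier exchanges on the same nitrogen: the anilide compounds 1 and 2 sit far apart (an 18-fold lower number from compound 1 to compound 2 (1.27 log units; beyond the scatter)), and the move from a phenyl to a benzyl group (a 14-fold lower number from compound 1 to compound 3 (1.14 log units; beyond the scatter)) was also large. Because these steps (an 18-fold lower number from compound 1 to compound 2 (1.27 log units; beyond the scatter), a 1.3-fold higher number from compound 2 to compound 3 (0.12 log units; within the scatter)) point in opposite directions, the direction for compound 4 is uncertain, and a step of modest size upward is expected (a 1.9-fold higher number from compound 3 to compound 4 (0.28 log units; within the scatter)).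

For compound 4 in this assay the estimated value is 150000 nM, with a range from 35000 nM to 900000 nM.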

Compound 4, half-maximal cytotoxic concentration: 460000 nM
Estimate against measurement, compound 4: 3.1-fold (0.49 log units) below, within the range that was stated.
By their numbers in this assay, from the lowest: compounds 2 and 3 (each within the scatter of the next); then compound 4; then compound 1.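

In this assay, putting 4-ethoxyphenyl on the amide-type nitrogen separates compound 4 clearly from the two compounds with the lowest numbers (a 5.8-fold higher number from compound 3 to compound 4 (0.76 log units; beyond the scatter)) (a 7.7-fold higher number from compound 2 to compound 4 (0.89 log units; beyond the scatter)), yet the number does not reach that of the 3-chlorophenyl amide (a 2.4-fold lower number from compound 1 to compound 4 (0.38 log units; beyond the scatter)). The phenyl amides compounds 1, 2 and 4 now occupy three separate levels, and compound 2 stays within the scatter of the benzyl amide compound 3, so in these compounds neither a phenyl nor a benzyl group on this nitrogen sets the number by itself, and what is attached to the ring matters at least as much. No measurement bearing on why these steps arise is available.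

With only one compound carrying an oxygen substituent, the compounds shown cannot separate the contribution of the ethoxy group from that of the change from benzyl to phenyl, which a 4-ethoxybenzyl amide would address directly. On these data alone, it also remains open where a 4-methoxyphenyl or 4-hydroxyphenyl group, or a phenyl ring bearing an amine or a carboxylic acid, would fall on this scale.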